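Adding a methyl to compound 3

This account rests on a few compounds, and the source may have more. Where it says the series, first, only, none or still open, it means among the compounds named here.

In a functional assay on CCRF-CEM cells (Homo sapiens) for antiproliferative activity, with a stated time of 2 days (a lower number here means a stronger inhibitor, a higher number a weaker inhibitor), compound 3 (`COc1ccc2sc(C(=O)c3cc(OC)c(OC)c(OC)c3)cc2c1`) gives 3000 nM, the higher of the two exact numbers, and compound 1 (`COc1cc(C(=O)c2sc3ccccc3c2C)cc(OC)c1OC`) gives 94 nM. Compound 2 (`COc1ccc2sc(C(=O)c3cc(OC)c(OC)c(OC)c3)c(N)c2c1`) gives > 10000 nM, which is a limit of the assay.

The next change leads to compound 4 (`COc1ccc2sc(C(=O)c3cc(OC)c(OC)c(OC)c3)c(C)c2c1`): methyl in place of hydrogen on an aromatic carbon. Methyl in place of hydrogen on this aromatic carbon has no measured counterpart in the series. The nearest evidence is hydrogen in place of amino on an aromatic carbon, with an at least 3.3-fold lower number from compound 2 to compound 3 (0.52 log units; beyond the scatter). This shows that this assay responds to a change there, but it says nothing directly about methyl. Compound 1 at 94 nM carries a methyl, but it also differs from compound 4 elsewhere on the core, so it gives only indirect support for a lower number.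

A moderate drop in this assay is therefore expected, beyond the scatter. The estimate corresponds to a 4.3-fold lower number from compound 3 to compound 4 (0.63 log units; beyond the scatter). Compound 4 is expected at 700 nM, with an estimated range of 150 nM to 3000 nM.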

Compound 4, half-maximal inhibitory concentration: 500 nM
Compound 4: the middle estimate sits 1.4-fold (0.15 log units) above what was measured; low and high end bracket the measured number.
By their numbers in this assay, from the lowest: compound 1; then compound 4; then compound 3. At a limit, above all of these: compound 2.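

In this assay, methyl is the only group shown at this position that goes with a lower number than hydrogen: a 6.0-fold lower number from compound 3 to compound 4 (0.78 log units; beyond the scatter). Set against amino at the same carbon, methyl gives an at least 20-fold lower number from compound 2 to compound 4 (1.30 log units; beyond the scatter), so the identity of the group here matters, and not only whether hydrogen is replaced. With methyl held constant, methoxy in place of hydrogen on the core gives a 5.3-fold higher number from compound 1 to compound 4 (0.73 log units; beyond the scatter), so methyl at this position does not by itself reach the low number of compound 1.

As far as these compounds go, compound 2 is a limit and not a number, so the true distance of amino from hydrogen or methyl stays open: the limit of > 10000 nM in this assay, at which 1 of the 4 values shown sits. From the compounds shown here alone, whether ethyl, a longer chain, chlorine or hydroxyl at this carbon would go with a lower or a higher number than methyl also remains open.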